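Iodo-to-hydrogen change on two cores: cytotoxicity notes

This account rests on a few compounds, and the source may have more. Where it says the series, first, only, none or still open, it means among the compounds named here.

Measured in an ADME assay on L1210/0 cells (Mus musculus) for cytotoxicity, with a stated time of 48 h; a lower number here means a stronger inhibitor, a higher number a weaker inhibitor:

compound 1, `O=C1O/C(=C\Cn2cc(I)c(=O)[nH]c2=O)C(OCc2ccccc2)=C1OCc1ccccc1`, 7500 nM
compound 2, `O=C1O/C(=C\Cn2ccc(=O)[nH]c2=O)C(OCc2ccccc2)=C1OCc1ccccc1`, 12900 nM
compound 3, `CC(=O)OCCOCn1cnc2c(Cl)nc(I)nc21`, 8600 nM

Compound 3 carries a different core from compound 1; the difference between the two cores is not broken down here. Compound 1 and compound 2 differ by hydrogen in place of iodo on an aromatic carbon, and in this assay that step is a 1.7-fold higher number from compound 1 to compound 2 (0.24 log units; within the scatter).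

Compound 4, `CC(=O)OCCOCn1cnc2c(Cl)ncnc21`, is not yet measured. From compound 3 it differs by hydrogen in place of iodo on an aromatic carbon. Within the data shown here, this is the same kind of change as the one from compound 1 to compound 2, but the surroundings are not identical: in compound 3 the carbon lies between two ring nitrogen atoms, meta to a chloro group, meta and para to a fused ring, while in compound 1 it is ortho to a group of 1 heavy atom, two atoms from the ring nitrogen, meta to a large group and para to a group of 1 heavy atom.

In this assay compound 4 is expected to give 13000 nM, between 6000 nM and 30000 nM, a step of a 1.5-fold higher number from compound 3 to compound 4 (0.18 log units; within the scatter); this expectation rests on compound 1 and compound 2, where the same change gave a 1.7-fold higher number from compound 1 to compound 2 (0.24 log units; within the scatter).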

Compound 4, half-maximal inhibitory concentration: 163000 nM
Beside the measured number, compound 4's estimate is 13-fold (1.10 log units) below it; measured number outside the range, above it.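

In this assay, hydrogen in place of iodo gives a 19-fold higher number from compound 3 to compound 4 (1.28 log units; beyond the scatter), a large step on this core, whereas the same change on the core of compound 1 stays within the scatter. The size of the step therefore does not carry from one core to the other in this series, as the two steps set side by side show: the same change on two cores in this assay, a 1.7-fold higher number (0.24 log units; within the scatter) from compound 1 to compound 2 and a 19-fold higher number (1.28 log units; beyond the scatter) from compound 3 to compound 4, 11-fold (1.04 log units) apart, beyond the scatter of two such steps

Among these compounds, with only one pair on each core, these results do not show which feature of the cores sets the two steps apart, nor what size the step would take on a further core.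

Going by these compounds, it remains open whether a bromo group, a methyl group or an amine on the same aromatic carbon of the core of compound 3 would give a number closer to that of compound 3 or that of compound 4. Also open, on these data alone, is whether the step keeps its size when the chloro group shared by compound 3 and compound 4 is replaced by an amine.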